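This account rests on a few compounds, and the source may have more. Where it says the series, first, only, none or still open, it means among the compounds named here.

Working notes on the series. Compound 1 `Cc1[nH]ncc1-c1ccc2nc(C3COc4ccccc4C3)oc2c1` in an assay on isolated protein for inhibition of Rho-associated protein kinase 2 (Homo sapiens) (on this read-out lower numbers stand for stronger inhibition and higher numbers for weaker inhibition), gives 9 nM. Compound 2 `Cc1[nH]ncc1-c1ccc2nc(C3COc4ccccc4C3)[nH]c2c1` gives 9 nM, so compound 1 and compound 2 stand level at the digits shown, and together they hold the highest of the three numbers. Among the measured compounds shown here, compound 3 `c1ccc2c(c1)CC(c1nc3ccc(-c4ccncc4)cc3[nH]1)CO2` gives 2 nM; against compound 1 this is the lowest number of the set, and the only measured step, a 4.5-fold lower number from compound 2 to compound 3 (0.65 log units; beyond the scatter), comes from the exchange of the five-membered heteroaryl for a six-membered one on the shared core.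

Compound 4 `Nc1nccc(-c2ccc3nc(C4COc5ccccc5C4)oc3c2)n1` is not yet measured. Relative to compound 1 the change is 2-aminopyrimidin-4-yl in place of 5-methyl-1H-pyrazol-4-yl on an aromatic carbon. The step that bears on it is a 4.5-fold lower number from compound 2 to compound 3 (0.65 log units; beyond the scatter), where a six-membered nitrogen heteroaryl replaced the same pyrazolyl group and the number fell modestly, beyond the scatter. The present change is of the same kind, five-membered ring out and six-membered ring in, although the entering group here also carries an amino group and more acceptors. A step in this assay of similar direction is therefore expected, a modest fall in the number or at most one near the edge of the scatter. For compound 4 the expected value is 5 nM, in the range 2 nM to 15 nM. The step this implies is estimated as a 1.8-fold lower number from compound 1 to compound 4 (0.26 log units; within the scatter).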

Compound 4, half-maximal inhibitory concentration: 27 nM
Compound 4: the middle estimate sits 5.4-fold (0.73 log units) below what was measured, outside the stated range (above it).
By their numbers in this assay, from the lowest: compound 3; then compounds 1 and 2 (each within the scatter of the next); then compound 4.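

In this assay, 2-aminopyrimidin-4-yl in place of 5-methyl-1H-pyrazol-4-yl on an aromatic carbon gives a 3.0-fold higher number from compound 1 to compound 4 (0.48 log units; beyond the scatter), so at this position a six-membered aromatic ring entering for the five-membered one does not by itself lower the number. The earlier step at this place, a 4.5-fold lower number from compound 2 to compound 3 (0.65 log units; beyond the scatter), ran the other way with pyridin-4-yl entering, so across these two pairs, which stand on different cores, the direction of the exchange follows the entering group and not ring size alone. No measurement in hand accounts for the higher number of compound 4 or for the opposite directions of the two steps.

The compounds shown leave open whether the step belongs to the amino group or to the pyrimidine ring, a question that plain pyrimidin-4-yl or 2-aminopyridin-4-yl on the core of compound 1 would separate. They also leave open whether pyridin-4-yl on the core of compound 1 would repeat the lower number seen on the core of compound 3.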